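Iodo to nitro at two ring positions in thiosemicarbazones

The source may report more compounds than this note shows. Statements on the series, on what has been measured and on what is new or still open speak of the compounds shown alone.

Compound 1, `C/C(=N\NC(=S)Nc1ccccc1I)c1ccccn1`, in a functional assay on MCF7 cells (Homo sapiens) for cytotoxicity, read by MTT assay, with a stated time of 48 h (on this read-out higher numbers stand for weaker inhibition and lower numbers for stronger inhibition), gives 4.1 nM.
Compound 2, `C/C(=N\NC(=S)Nc1cccc(I)c1)c1ccccn1`, in this assay gives 45 nM.
Compound 3, `C/C(=N\NC(=S)Nc1ccccc1[N+](=O)[O-])c1ccccn1`, in this assay gives 5.7 nM.

Compound 1 and compound 2 have the same atoms joined differently; the difference between the two cores is not broken down here, and the values show compound 2 with the highest number of the three, beyond the scatter from both others. The change nitro in place of iodo on an aromatic carbon gave a 1.4-fold higher number from compound 1 to compound 3 (0.14 log units; within the scatter). Compound 4, `C/C(=N\NC(=S)Nc1cccc([N+](=O)[O-])c1)c1ccccn1`, differs from compound 2 by nitro in place of iodo on an aromatic carbon, the same kind of change, though here the place is meta to a large group rather than ortho to a large group. Resting on that earlier step from compound 1 to compound 3, the step from compound 2 to compound 4 in this assay is expected to be small, about a 1.2-fold higher number from compound 2 to compound 4 (0.09 log units; within the scatter). Compound 4 is therefore estimated at 55 nM, between 15 nM and 200 nM.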

Compound 4, half-maximal inhibitory concentration: 38 nM
Beside the measured number, compound 4's estimate is 1.4-fold (0.16 log units) above it, and the stated range covers the measured number.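

In this assay, nitro in place of iodo gives a 1.2-fold lower number from compound 2 to compound 4 (0.07 log units; within the scatter), and this step agrees with the one seen on the core of compound 1: the same change on two cores in this assay, a 1.4-fold higher number (0.14 log units; within the scatter) from compound 1 to compound 3 and a 1.2-fold lower number (0.07 log units; within the scatter) from compound 2 to compound 4, 1.6-fold (0.22 log units) apart, within the scatter of two such steps. In these two pairs, then, the change carries from one core to the other without a step beyond the scatter. For the compounds shown here, this does not show that it would carry to other cores or ring places, as the finding rests on only two pairs in a single assay.

The compounds shown leave open how an amine or a carboxylic acid in the place of iodo or nitro would read in this assay. They also leave open whether the step would hold on a core carrying a longer chain.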